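A few compounds are considered here, and "the series" means these few. Any claim that something is new, unique, unknown or untested is made for them only; others in the source may bear on it.

Among the measured compounds shown here, in a physicochemical assay for lipophilicity (a lower number here means a more polar compound, a higher number a more lipophilic compound), compound 3 `C[C@H]1CC[C@@H]2[C@@H](OC(=O)[C@]23CC(c2ccc(Br)cc2)N(c2ccccc2)O3)[C@]2(C)C(=O)C=C[C@@]12O` gives 4, the highest of the three numbers so far, well clear of compound 1 `C[C@H]1CC[C@@H]2[C@@H](OC(=O)[C@]23CC(c2ccc([N+](=O)[O-])cc2)=NO3)[C@]2(C)C(=O)C=C[C@@]12O` at 1.37 and compound 2 `COc1ccc(C2=NO[C@]3(C2)C(=O)O[C@@H]2[C@H]3CC[C@H](C)[C@]3(O)C=CC(=O)[C@@]23C)cc1OC` at 1.06. Compound 4 `COc1ccc(C2C[C@@]3(ON2c2ccccc2)C(=O)O[C@@H]2[C@H]3CC[C@H](C)[C@]3(O)C=CC(=O)[C@@]23C)cc1` differs from compound 3 in one place: methoxy in place of bromo on an aromatic carbon, para to a large group. For the measured compounds named here, only one measured step bears on this, a number 0.31 log units lower from compound 1 to compound 2 (beyond the scatter). Going by the values given here, that modest step is a different exchange, with 3,4-dimethoxyphenyl in place of 4-nitrophenyl, and no measured step involves bromo, so it suggests a direction more than a size. A fall in this assay somewhat larger than that step is expected. The estimated step is a number 0.60 log units lower from compound 3 to compound 4 (beyond the scatter). For compound 4 the expected value is 3.4, with a range of 2.9 to 3.9.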

Compound 4, partition coefficient: 3.25
Beside the measured number, compound 4's estimate is 0.15 log units above it; the measured number falls inside the stated range.
By their numbers in this assay, from the lowest: compound 2; then compound 1; then compound 4; then compound 3.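

In this assay, methoxy in place of bromo on an aromatic carbon, para to a large group, gives a number 0.75 log units lower from compound 3 to compound 4 (beyond the scatter). Among the compounds shown here, this is the first reading of a single-group exchange at this place, since the earlier step, a number 0.31 log units lower from compound 1 to compound 2 (beyond the scatter), involved neither bromo nor a lone methoxy. Nothing available accounts for the size of this step. Still open, on these data alone, is how an amine, a carboxylic acid or a chloro group would read at this place, and whether the same exchange gives a similar step on the core of compound 1.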